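Adding a Chloro Group to Compound 1

A few compounds are considered here, and "the series" means these few. Any claim that something is new, unique, unknown or untested is made for them only; others in the source may bear on it.

Measured so far:
compound 1, `O=C(O)CCCSCCN1C(=O)OC[C@@H]1/C=C/[C@@H](O)Cc1ccccc1`: 36 nM
compound 2, `CCc1cccc(C[C@H](O)/C=C/[C@H]2CSC(=O)N2CCSCCCC(=O)O)c1`: 1.9 nM

In a functional assay on CHO cells for agonist activity at prostaglandin E2 receptor EP4 subtype (Rattus norvegicus), read by cAMP accumulation and immunoassay, with a stated time of 10 min (a higher number here means that more compound is needed for the effect, a lower number that less compound is needed), compound 1 gives 36 nM, the highest number of the two; compound 2 gives 1.9 nM, a gap beyond the usual scatter. Compound 3, `O=C(O)CCCSCCN1C(=O)OC[C@@H]1/C=C/[C@@H](O)Cc1cccc(Cl)c1`, has not yet been measured. It differs from compound 1 in one place: chloro in place of hydrogen on an aromatic carbon. For the measured compounds named here, no measured pair shows this change on its own, so the step is expected to be modest, toward a lower number: a 2.4-fold lower number from compound 1 to compound 3 (0.38 log units; beyond the scatter). Compound 3 is expected to give about 15 nM, in the range 5 nM to 60 nM.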

Compound 3, half-maximal effective concentration: 23 nM
Compound 3: middle estimate off by 1.5-fold (0.19 log units), on the low side; the range from low to high includes it.
By their numbers in this assay, from the lowest: compound 2; then compounds 3 and 1 (each within the scatter of the next).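

In this assay, for the compounds shown here, the change of hydrogen to chloro on this aromatic carbon gives a 1.6-fold lower number from compound 1 to compound 3 (0.19 log units; within the scatter) and is the first direct reading of this swap. At this position of the shared core, the added chlorine atom therefore produces no shift that can be told apart from repeat measurements. Nothing at hand gives a reason for this result.

As far as these compounds go, whether a methoxy group or a fluorine atom on the same carbon would give a step beyond the scatter stays open. The compounds shown also leave open how chloro would read on another carbon of this ring.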